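This account rests on a few compounds, and the source may have more. Where it says the series, first, only, none or still open, it means among the compounds named here.

Compound 1 `CCO/N=C/c1c(N)ncnc1Oc1ccc(NC(=O)C2(C(=O)Nc3ccc(F)cc3)CC2)cc1F` gives 3.41 in a physicochemical assay for lipophilicity, using the shake flask method (a lower number here means a more polar compound, a higher number a more lipophilic compound), and compound 2 `CCOC(=O)CO/N=C/c1c(N)ncnc1Oc1ccc(NC(=O)C2(C(=O)Nc3ccc(F)cc3)CC2)cc1F` gives 3.15. The one step between them, a number 0.26 log units lower from compound 1 to compound 2 (within the scatter), leaves compound 2 within the scatter of compound 1, the only other number shown. Compound 3 `Nc1ncnc(Oc2ccc(NC(=O)C3(C(=O)Nc4ccc(F)cc4)CC3)cc2F)c1/C=N/OCCCN1CCCC1` differs from compound 2 by 2-(pyrrolidin-1-yl)ethyl in place of ethoxycarbonyl on a saturated chain carbon bound to an oxygen on an unsaturated carbon. Within the data shown here, only the step from compound 1 to compound 2 touches the same place, and it was within the scatter; removing the ethoxycarbonyl alone would be expected to undo that step. Among the measured compounds shown here, no measured step covers the entering 2-(pyrrolidin-1-yl)ethyl group, so the expectation rests on little. For compound 3 the number in this assay is estimated at 2.6, with a range from 1.8 to 3.4, which means an expected step of a number 0.55 log units lower from compound 2 to compound 3 (beyond the scatter) downward, beyond the scatter but with wide uncertainty.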

Compound 3, partition coefficient: 3.82
Beside the measured number, compound 3's estimate is 1.22 log units below it; measured number outside the range, above it.
By their numbers in this assay, from the lowest: compounds 2 and 1 (each within the scatter of the next); then compound 3.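

In this assay, the place on a saturated chain carbon bound to an oxygen on an unsaturated carbon now shows a change beyond the scatter: 2-(pyrrolidin-1-yl)ethyl in place of ethoxycarbonyl gives a number 0.67 log units higher from compound 2 to compound 3 (beyond the scatter), whereas the earlier step stayed within it. Measured against the simpler side chain, the new group also gives a number 0.41 log units higher from compound 1 to compound 3 (beyond the scatter), so compound 3 has the highest number of the three, and a chain ending in a nitrogen-containing ring did not bring the number down. Nothing shown here explains this rise. Going by these compounds, it remains open whether a shorter or longer chain carrying the same ring, or a dimethylamino group in place of that ring, would give a similar number. On these data alone, a carboxylic acid in place of the ethoxycarbonyl group also remains open, so these three compounds cannot establish a trend at this position.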